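The compounds below may be only part of what the source reports. "The series", "measured", "known", "first", "only" and "open" are said of these compounds alone.

Compound 1 `COC(=O)N[C@H](C(=O)NN(CCC[C@@](O)(Cc1ccccc1)C(=O)N[C@H]1c2ccccc2C[C@H]1O)Cc1ccc(F)cc1)C(C)(C)C` gives > 10000 nM (a limit)
Compound 2 `COC(=O)N[C@H](C(=O)NN(CCC[C@@](O)(Cc1ccccc1)C(=O)N[C@H]1c2ccccc2C[C@H]1O)Cc1ccc(-c2csc(C)n2)cc1)C(C)(C)C` gives > 10000 nM (a limit)
Compound 3 `COC(=O)N[C@H](C(=O)NN(CCC[C@@](O)(Cc1ccccc1)C(=O)N[C@H]1c2ccccc2C[C@H]1O)Cc1ccc(-c2ccccc2)cc1)C(C)(C)C` gives 7500 nM

In an ADME assay on MT4 cells (Homo sapiens) for cytotoxicity (on this read-out lower numbers stand for higher toxicity in this test and higher numbers for lower toxicity in this test), compound 3 gives 7500 nM and is the only one of the three with an actual number. Compound 1 and compound 2 stand at the limit of > 10000 nM in this assay, at which 2 of the 3 values shown sit, and so give limits, not numbers.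

Compound 4 `COC(=O)N[C@H](C(=O)NN(CCC[C@@](O)(Cc1ccccc1)C(=O)N[C@H]1c2ccccc2C[C@H]1O)Cc1ccc(-c2ccsc2)cc1)C(C)(C)C` differs from compound 3 in one place, with thiophen-3-yl in place of phenyl on an aromatic carbon

Among the measured compounds shown here, two measured steps bear on this change. One is an at least 1.3-fold lower number from compound 2 to compound 3 (0.12 log units; that floor lies within the scatter) and the other is an at least 1.3-fold lower number from compound 1 to compound 3 (0.12 log units; that floor lies within the scatter) and the floor of each lies within the scatter. No step beyond the scatter is therefore expected, so the estimate is a 1.2-fold higher number from compound 3 to compound 4 (0.08 log units; within the scatter) in this assay and a limit is just as likely as a number. Compound 4 is estimated at 9000 nM (expected range 4500 nM to 18000 nM).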

Compound 4, half-maximal cytotoxic concentration: > 10000 nM
Compound 4 gave a limit, no number; the forecaster's own chance of this, stated with the estimate: 50%; middle value at least 1.1-fold (0.04 log units) away from the limit.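

In this assay, thiophen-3-yl in place of phenyl, para to a large group, gives an at least 1.3-fold higher number from compound 3 to compound 4 (0.12 log units; that floor lies within the scatter). A five-membered sulfur-containing ring at this position therefore shows no separation from phenyl beyond the scatter, so compound 3 cannot be called the most toxic of the set. The steps linking compound 4 with compound 1 and compound 2 cannot be read, and one ceiling governs all three: the limit of > 10000 nM in this assay, at which 3 of the 4 values shown sit.

As far as these compounds go, how far these compounds lie past that limit stays open, as does whether an amine or a carboxylic acid at this position would move the number beyond the scatter.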